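Heteroaryl amide swap on the shared core: compound 3 pending

The source may report more compounds than this note shows. Statements on the series, on what has been measured and on what is new or still open speak of the compounds shown alone.

Measured so far:
compound 1 `Cc1c(NC(=O)COc2ccc(/C=C3\SC(=O)NC3=O)cc2)c(=O)n(-c2ccccc2)n1C` — < 100000 nM in a functional assay on HepG2 cells (Homo sapiens) for cytotoxicity, read by sulforhodamine B assay, with a stated time of 48 h; a lower number here means a stronger inhibitor of growth, a higher number a weaker inhibitor of growth
compound 2 `Cc1cnc(NC(=O)COc2ccc(/C=C3\SC(=O)NC3=O)cc2)s1` — < 100000 nM in this assay

Both figures in this assay are limits of the assay rather than numbers. For compound 1 the value < 100000 nM is such a limit. For compound 2 the value < 100000 nM is likewise only a limit. Among the measured compounds shown here, compound 2 therefore stands where compound 1 stands: the limit of < 100000 nM in this assay, at which 2 of the 2 values shown sit, and no step between the two can be counted from these limits.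

Compound 3 `Cc1cc(NC(=O)COc2ccc(/C=C3\SC(=O)NC3=O)cc2)no1` differs from compound 2 by 5-methyl-1,2-oxazol-3-yl in place of 5-methyl-1,3-thiazol-2-yl on an amide-type nitrogen. For the measured compounds named here, with no measured step, the change from compound 2 to compound 3 in this assay is expected to give none beyond the scatter, as a step that the limit leaves unreadable from compound 2 to compound 3. Compound 3 is expected at 60000 nM, with a range from 15000 nM to 100000 nM, most likely reported again as a limit.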

Compound 3, concentration for total growth inhibition: < 100000 nM
Compound 3: a limit, no number; the forecaster's own chance of this, stated with the estimate: 70%; the middle value does not contradict the limit.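

No step can be read from compound 2 to compound 3, since each gives only a limit of the assay in this assay: the limit of < 100000 nM in this assay, at which 3 of the 3 values shown sit.

The compounds shown leave open whether the group on the amide-type nitrogen shifts the read-out at all in this assay, with no number yet for compound 1, compound 2 or compound 3.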